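Swapping the Bromophenyl for a Dimethoxyphenyl on the Chain

The source may hold more compounds than are shown below. What is called first, only, known or untested is meant among the compounds shown, and "the series" means these compounds.

Of the compounds shown here, three sharing one core have been tested in a functional assay on PC-3 cells (Homo sapiens) for cytotoxicity, read by MTT assay, with a stated time of 72 h; a lower number here means a stronger inhibitor, a higher number a weaker inhibitor. Compound 1 `COc1ccc(OC)c(/C=C/C(=O)Nc2cc3c(Nc4ccc(F)c(Cl)c4)ncnc3cc2O[C@H]2CCOC2)c1` gives 8730 nM, compound 2 `COc1cc(/C=C/C(=O)Nc2cc3c(Nc4ccc(F)c(Cl)c4)ncnc3cc2O[C@H]2CCOC2)cc(OC)c1OC` gives 20500 nM, and compound 3 `O=C(/C=C/c1ccc(Br)cc1)Nc1cc2c(Nc3ccc(F)c(Cl)c3)ncnc2cc1O[C@H]1CCOC1` gives 28200 nM, the highest number shown, although its gap to compound 2 lies within the scatter while its gap to compound 1 does not. Compound 4 `COc1ccc(/C=C/C(=O)Nc2cc3c(Nc4ccc(F)c(Cl)c4)ncnc3cc2O[C@H]2CCOC2)c(OC)c1` is the untested member and differs from compound 3 in one place: 2,4-dimethoxyphenyl in place of 4-bromophenyl on a double-bonded chain carbon bound to a double-bonded chain carbon. Among the compounds with values here, two measured steps bear on this. Moving from a dimethoxyphenyl to the bromophenyl gave a 3.2-fold higher number from compound 1 to compound 3 (0.51 log units; beyond the scatter), whereas moving from the trimethoxyphenyl gave a 1.4-fold higher number from compound 2 to compound 3 (0.14 log units; within the scatter). Returning to a dimethoxyphenyl is therefore expected to lower the number modestly, giving a 2.6-fold lower number from compound 3 to compound 4 (0.41 log units; beyond the scatter). Compound 4 is estimated at 11000 nM, with a range from 5000 nM to 25000 nM.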

Compound 4, half-maximal inhibitory concentration: 2760 nM
For compound 4 the middle estimate is 4.0-fold (0.60 log units) above the measured one; measured number outside the range, below it.
By their numbers in this assay, from the lowest: compound 4; then compound 1; then compounds 2 and 3 (each within the scatter of the next).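

The pattern of methoxy groups on the ring matters, not only their presence: 2,4-dimethoxyphenyl in place of 2,5-dimethoxyphenyl gives a 3.2-fold lower number from compound 1 to compound 4 (0.50 log units; beyond the scatter). In place of 3,4,5-trimethoxyphenyl it gives a 7.4-fold lower number from compound 2 to compound 4 (0.87 log units; beyond the scatter), and in place of 4-bromophenyl it gives a 10-fold lower number from compound 3 to compound 4 (1.01 log units; beyond the scatter). Within the data shown here, compound 4 is therefore the strongest inhibitor of the four, and this place on the chain allows a wider spread than the earlier compounds showed. Nothing shown here explains the difference. From the compounds shown here alone, whether a phenyl ring carrying an amine or a carboxylic acid would match compound 4 stays open.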